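Benzyloxy addition on a weak bis-cinnamoyl phenol

The source may hold more compounds than are shown below. What is called first, only, known or untested is meant among the compounds shown, and "the series" means these compounds.

Working notes on the series. For the measured compounds named here, compound 1 `Cc1cc(O)c(C(=O)/C=C/c2ccc(Cl)cc2)c(-c2ccccc2)c1C(=O)/C=C/c1ccc(Cl)cc1` is the only member with a numerical result in a functional assay on MCF7 cells (Homo sapiens) for cytotoxicity, read by MTT assay, with a stated time of 24 h; a lower number here means a stronger inhibitor, a higher number a weaker inhibitor: compound 1 gives 10000 nM, a weak figure standing alone. Compound 2 `Cc1cc(O)c(C(=O)/C=C/c2ccccc2Cl)c(-c2ccccc2)c1C(=O)/C=C/c1ccccc1Cl` is recorded in this assay as "not active" (no number reported), and compound 3 `Cc1cc(O)c(C(=O)/C=C/c2ccccc2)c(-c2ccc(OCc3ccccc3)cc2)c1C(=O)/C=C/c1ccccc1` in this assay as "not active" (no number reported). Compound 4 `Cc1cc(O)c(C(=O)/C=C/c2ccc(Cl)cc2)c(-c2ccc(OCc3ccccc3)cc2)c1C(=O)/C=C/c1ccc(Cl)cc1` differs from compound 1 by benzyloxy in place of hydrogen on an aromatic carbon. Going by the values given here, no pair of measured compounds supplies a step for this change. Compound 3 already carries the benzyloxy group and is recorded as "not active" (no number reported), so no gain is expected; the expected step is a 1.5-fold higher number from compound 1 to compound 4 (0.18 log units; within the scatter), within scatter or toward weaker. For compound 4 the estimate in this assay is 15000 nM, with a range of 5000 nM to 50000 nM, and a real chance that only inactivity is reported.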

Compound 4, half-maximal inhibitory concentration: "not active" (no number reported)
No number was reported for compound 4; there is nothing to compare the estimate with.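

For the compounds shown here, compound 4 is recorded as "not active" with no number, so no step from compound 1 can be read. The compounds shown leave open how far the benzyloxy group shifts the result in this assay. No measured evidence bears on this outcome.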